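Series notes: varying the group on the saturated carbon

A few compounds are considered here, and "the series" means these few. Any claim that something is new, unique, unknown or untested is made for them only; others in the source may bear on it.

Among the compounds with values here, compound 2 `C/C(=C\C(=O)Nc1ccccc1OCCCC(=O)O)c1ccc2c(ccn2C(c2ccccc2)C(C)C)c1` sits highest of the two numbers measured so far: in an assay on Prostate gland for inhibition of steroid 5-alpha-reductase (Rattus norvegicus) (on this read-out lower numbers stand for stronger inhibition and higher numbers for weaker inhibition), compound 2 gives 25 nM. Within the data shown here, its only neighbour is compound 1 `CCCCC(c1ccccc1)n1ccc2cc(/C(C)=C/C(=O)Nc3ccccc3OCCCC(=O)O)ccc21`, which in this assay gives 9.8 nM; the step of a 2.6-fold higher number from compound 1 to compound 2 (0.41 log units; beyond the scatter) is the single measured change at this position. Compound 3 `COc1ccc(C(c2ccccc2)n2ccc3cc(/C(C)=C/C(=O)Nc4ccccc4OCCCC(=O)O)ccc32)cc1` is not yet measured. It differs from compound 2 by 4-methoxyphenyl in place of isopropyl on a saturated chain carbon bound to an aromatic carbon and an aromatic nitrogen. Among the measured compounds shown here, the one measured step bears only loosely on this change: it exchanged one saturated chain for another, whereas here a group carrying an aromatic ring enters. That step was modest, and the move from butyl to isopropyl went toward weaker inhibition, so a modest move is expected here as well, though its direction cannot be fixed from two compounds alone. Compound 3 is therefore estimated at 20 nM, within 6 nM to 65 nM. The expected step is a 1.3-fold lower number from compound 2 to compound 3 (0.10 log units; within the scatter); the wide range reflects that nothing measured covers an aromatic ring at this place.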

Compound 3, half-maximal inhibitory concentration: 8.8 nM
Estimate against measurement, compound 3: 2.3-fold (0.36 log units) above, and the stated range covers the measured number.
By their numbers in this assay, from the lowest: compounds 3 and 1 (each within the scatter of the next); then compound 2.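

Within the data shown here, on the saturated chain carbon bound to an aromatic carbon and an aromatic nitrogen, a group carrying an aromatic ring is accepted in this assay: 4-methoxyphenyl in place of isopropyl gives a 2.8-fold lower number from compound 2 to compound 3 (0.45 log units; beyond the scatter), which is the first sign that this place takes more than a saturated chain. Against butyl, the same group gives a 1.1-fold lower number from compound 1 to compound 3 (0.05 log units; within the scatter), so 4-methoxyphenyl and butyl cannot be told apart here, and compound 2, with isopropyl, is the only one of the three that stands apart, its steps to both others lying beyond the scatter. No supporting data bear on why isopropyl reads differently from the other two groups.

The compounds shown do not separate the contribution of the aromatic ring from that of its methoxy group, a question that an unsubstituted phenyl at this place would address. Also open, as far as these compounds go, is how a chain longer than butyl, or a group bearing an amine, would read in this assay.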